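A few compounds are considered here, and "the series" means these few. Any claim that something is new, unique, unknown or untested is made for them only; others in the source may bear on it.

Of the compounds shown here, three sharing one core have been tested in an ADME assay on cells (Lymphocyte, Homo sapiens) for cytotoxicity, read by MTT assay, with a stated time of 48 h; on this read-out lower numbers stand for stronger inhibition and higher numbers for weaker inhibition. Compound 1 `COC(=O)/C(=C\c1ccc(OC(=O)c2ccccc2OC)cc1)Sc1ccnc2cc(Cl)ccc12` gives > 100000 nM in this assay, which is a limit of the assay and not a number. On the numbers shown, compound 1 thus stands at the weak end, at the limit of > 100000 nM in this assay, at which 1 of the 3 values shown sits. Compound 2 `COC(=O)/C(=C\c1ccc(OC(=O)c2ccc(OC)cc2OC)cc1)Sc1ccnc2cc(Cl)ccc12` gives 41600 nM, and compound 3 `COC(=O)/C(=C\c1ccc(OC(=O)c2cc(OC)cc(OC)c2OC)cc1)Sc1ccnc2cc(Cl)ccc12` gives 74000 nM. Compound 4 `COC(=O)/C(=C\c1ccc(OC(=O)c2cc(OC)c(OC)cc2OC)cc1)Sc1ccnc2cc(Cl)ccc12` has not been measured; it differs from compound 1 by 2,4,5-trimethoxyphenyl in place of 2-methoxyphenyl on a carbonyl carbon. Among the compounds with values here, the steps that bear on this change are an at least 2.4-fold lower number from compound 1 to compound 2 (0.38 log units; beyond the scatter) and an at least 1.3-fold lower number from compound 1 to compound 3 (0.13 log units; that floor lies within the scatter), while a 1.8-fold higher number from compound 2 to compound 3 (0.25 log units; within the scatter). Adding methoxy groups therefore gave lower numbers once beyond the scatter and once within it. Compound 4 is expected to show an at least 1.6-fold lower number from compound 1 to compound 4 (0.22 log units; that floor lies within the scatter), a modest downward step. Compound 4 is estimated at 60000 nM, within 30000 nM to 150000 nM.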

Compound 4, half-maximal inhibitory concentration: 52500 nM
Beside the measured number, compound 4's estimate is 1.1-fold (0.06 log units) above it, within the range that was stated.
By their numbers in this assay, from the lowest: compounds 2, 4 and 3 (each within the scatter of the next). At a limit, above all of these: compound 1.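

In this assay, a third arrangement of methoxy groups falls in with the other two, with a 1.4-fold lower number from compound 3 to compound 4 (0.15 log units; within the scatter) and a 1.3-fold higher number from compound 2 to compound 4 (0.10 log units; within the scatter), so no difference can be read among compound 2, compound 3 and compound 4. Against compound 1, the change gives an at least 1.9-fold lower number from compound 1 to compound 4 (0.27 log units; that floor lies within the scatter), which is a floor and not an exact size. Compound 1 stands at a limit of the assay and not at a number: the limit of > 100000 nM in this assay, at which 1 of the 4 values shown sits.

The compounds shown leave open how an amine or a carboxylic acid on this aromatic ring, or ethoxy in place of methoxy, would read in this assay.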